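The source may hold more compounds than are shown below. What is called first, only, known or untested is meant among the compounds shown, and "the series" means these compounds.

Compound 1 `O=C(CCC(=O)OCCCCCCSc1ccc([N+](=O)[O-])c2nonc12)Nc1ccccc1Cl`: 2750 nM
Compound 2 `Cc1ccccc1NC(=O)CCC(=O)OCCCCCCSc1ccc([N+](=O)[O-])c2nonc12`: 4200 nM
Compound 3 `Cc1ccc(NC(=O)CCC(=O)OCCCCCCSc2ccc([N+](=O)[O-])c3nonc23)cc1`: 5240 nM

In a functional assay on A549 cells (Homo sapiens) for inhibition, read by MTT assay, with a stated time of 72 h (a higher number here means a weaker inhibitor, a lower number a stronger inhibitor), compound 3 sits at the upper end of these three numbers, yet all its steps to the others stay within the scatter: a 1.9-fold higher number from compound 1 to compound 3 (0.28 log units; within the scatter) and a 1.2-fold higher number from compound 2 to compound 3 (0.10 log units; within the scatter), as does a 1.5-fold higher number from compound 1 to compound 2 (0.18 log units; within the scatter). Compound 4 `COc1ccc(NC(=O)CCC(=O)OCCCCCCSc2ccc([N+](=O)[O-])c3nonc23)cc1OC` differs from compound 3 by 3,4-dimethoxyphenyl in place of 4-methylphenyl on an amide-type nitrogen. Within the data shown here, none of the measured steps brings in a methoxy group; the three steps that change the group on the amide-type nitrogen all remain within the scatter, so no step beyond the scatter is expected in this assay. Compound 4 is therefore estimated at 5500 nM, with a range from 2000 nM to 15000 nM. The expected step of a 1.0-fold higher number from compound 3 to compound 4 (0.02 log units; within the scatter) is thus one within the scatter.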

Compound 4, half-maximal inhibitory concentration: 3890 nM
The estimate for compound 4 lay 1.4-fold (0.15 log units) above the measured number, within the range that was stated.
By their numbers in this assay, from the lowest: compounds 1, 4, 2 and 3 (each within the scatter of the next).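

In this assay, among these compounds, the 3,4-dimethoxyphenyl group, the only group here on the amide-type nitrogen with oxygen atoms and hydrogen-bond acceptors, gives a 1.3-fold lower number from compound 3 to compound 4 (0.13 log units; within the scatter) and a 1.1-fold lower number from compound 2 to compound 4 (0.03 log units; within the scatter) and a 1.4-fold higher number from compound 1 to compound 4 (0.15 log units; within the scatter). This position therefore accepts a larger group of 10 heavy atoms with no step beyond the scatter, extending what the chloro and methyl groups showed. No measurement here offers an explanation for this result. The compounds shown leave open whether a phenyl group carrying an amine or a carboxylic acid on this nitrogen would produce a step beyond the scatter.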